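This account rests on a few compounds, and the source may have more. Where it says the series, first, only, none or still open, it means among the compounds named here.

Measured compounds:
- Compound 1, `NC1=NC2(CCOCC2)N(OCCCOc2ccc(Cl)cc2)C(N)=N1` — "not determined" (no result reported) in a functional assay on HepG2 cells (Homo sapiens) for antiproliferative activity, read by MTT assay, with a stated time of 72 h; on this read-out lower numbers stand for stronger inhibition and higher numbers for weaker inhibition
- Compound 2, `NC1=NC2(CCOCC2)N(OCCCOc2ccccc2Cl)C(N)=N1` — 1750 nM
- Compound 3, `NC1=NC2(CCOCC2)N(OCCCOc2ccc(Cl)cc2Cl)C(N)=N1` — "not determined" (no result reported) in this assay

Compound 3 stands on no number at all: it is one of two entries in this series, together with compound 1, for which this assay gave no reported result. The only measured reference in the series is compound 2, which gives 1750 nM in this assay.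

Compound 4, `Cc1cc(C)cc(OCCCON2C(N)=NC(N)=NC23CCOCC3)c1`, differs from compound 3 in a single place: 3,5-dimethylphenyl in place of 2,4-dichlorophenyl on an oxygen on a saturated carbon. Both groups are the same size in heavy atoms, carry no hydrogen-bond donors or acceptors and bear no charge; what changes is that the two chlorine atoms of the 2,4-dichlorophenyl are gone and two carbons of the 3,5-dimethylphenyl take their place.

Among the measured compounds shown here, because compound 3 has no result, no step from it to compound 4 can be sized, and no other step between measured compounds is available. For the measured compounds named here, the only anchor is compound 2, whose value 1750 nM places the whole series in the micromolar region. Compound 4 is therefore expected to land near that level, without a direction that can be argued from the data. The estimate for compound 4 in this assay is 2000 nM, with a range from 500 nM to 8000 nM.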

Compound 4, half-maximal inhibitory concentration: 680 nM
Beside the measured number, compound 4's estimate is 2.9-fold (0.47 log units) above it; measured number inside the range.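

In this assay, the group on an oxygen on a saturated carbon proves able to shift the result, even with the shared core left untouched: 3,5-dimethylphenyl in place of 2-chlorophenyl gives a 2.6-fold lower number from compound 2 to compound 4 (0.41 log units; beyond the scatter), a modest step but one that lies beyond the usual scatter. A lower number here means stronger inhibition, so a chlorine on this ring is not needed for activity in these cells, and the all-carbon 3,5-dimethylphenyl does better than the 2-chlorophenyl. This single pair swaps the kind of substituent and its place on the ring together, and nothing shown here accounts for the difference.

The steps involving compound 1 and compound 3 cannot be read, as neither has a number, which leaves open what the 2,4-dichlorophenyl ring of compound 3 would do next to either measured ring. Also open, going by these compounds, is how the result would respond to a methoxy group, an amine or a carboxylic acid on the ring, or to a longer chain linking the ring to the shared core.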